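Swapping chloro for methoxy beside a sulfonamide

The source may hold more compounds than are shown below. What is called first, only, known or untested is meant among the compounds shown, and "the series" means these compounds.

Of the compounds shown here, two sharing one core have been measured for how strongly they hold back the growth of a human colon cancer cell line, a functional assay on HCT-116 cells (Homo sapiens) for antiproliferative activity, read by MTT assay, with a stated time of 72 h; on this read-out higher numbers stand for weaker inhibition and lower numbers for stronger inhibition. Compound 1 `COc1ncc(-c2ccc3nc(NC(=O)NCCN4CCCCC4)sc3c2)cc1NS(=O)(=O)c1ccc(F)cc1` gives 610 nM. Compound 2 `CCN(CC)CCNC(=O)Nc1nc2ccc(-c3cnc(Cl)c(NS(=O)(=O)c4ccc(F)cc4)c3)cc2s1` gives 920 nM. Among the measured compounds shown here, these two numbers lie within the usual scatter of each other, so on the evidence at hand the two compounds cannot be told apart; compound 2 is simply the one with the higher reading. Compounds 1 and 2 differ in two places at once, so neither difference can be assigned a step of its own.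

Compound 3 `CCN(CC)CCNC(=O)Nc1nc2ccc(-c3cnc(OC)c(NS(=O)(=O)c4ccc(F)cc4)c3)cc2s1` is not yet measured. It keeps the tail of compound 2 and changes only one place: methoxy in place of chloro on an aromatic carbon. For the measured compounds named here, compound 1 already carries this methoxy group, and its value of 610 nM stays within scatter of compound 2, which is the only guide available. A step from compound 2 to compound 3 of a 1.2-fold lower number from compound 2 to compound 3 (0.09 log units; within the scatter) in this assay is therefore expected, meaning no change beyond the scatter. Compound 3 is estimated at 750 nM, with a range from 350 nM to 1600 nM.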

Compound 3, half-maximal inhibitory concentration: 300 nM
Beside the measured number, compound 3's estimate is 2.5-fold (0.40 log units) above it; the measured number lies below the stated range.
By their numbers in this assay, from the lowest: compound 3; then compounds 1 and 2 (each within the scatter of the next).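

In this assay, the methoxy group in place of chloro on this aromatic carbon, next to the ring nitrogen and ortho to a ((4-fluorophenyl)sulfonyl)amino group, gives a 3.1-fold lower number from compound 2 to compound 3 (0.49 log units; beyond the scatter) and so shows a modest gain that the earlier pair, differing in two places at once, could not isolate. The tail counts as well: with the methoxy group kept, diethylamino in place of piperidin-1-yl gives a 2.0-fold lower number from compound 1 to compound 3 (0.31 log units; beyond the scatter), which means that the two changes separating compound 1 from compound 2 pull in opposite directions and that their readings, within the scatter of each other, hid two real differences. Nothing at hand explains why either change moves the reading.

On these data alone, at this aromatic carbon, only chloro and methoxy can be compared so far, so it remains open how a fluoro, methyl or ethoxy group would read. As far as these compounds go, it is also open how chloro would read alongside the piperidin-1-yl tail, a pairing that would test whether the two steps simply add together.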